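Fluoro Replaces Methyl on a Shared Core

The compounds below may be only part of what the source reports. "The series", "measured", "known", "first", "only" and "open" are said of these compounds alone.

Three close relatives on one shared core have been measured in a toxicity assay on the whole organism with Rattus norvegicus as the target, at a dose of 100 mg/kg by the oral route; a lower number here means a weaker effect, a higher number a stronger effect of the compound at the dose given. Compound 1, `Cc1ccccc1OCC1=NCCO1`, gives 10%. Compound 2, `Cc1cccc(OCC2=NCCO2)c1`, gives 15%, and compound 3, `Cc1ccc(OCC2=NCCO2)c(C)c1`, gives 15%. On the numbers shown, compound 1 holds the lowest of the three, yet its gap to compound 2 and its gap to compound 3 both lie within the usual scatter, so the three compounds cannot be told apart in this assay. Within the data shown here, the one step measured between two compounds that differ in a single place, a number 5 percentage points higher from compound 1 to compound 3 (within the scatter), also stays within the scatter.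

The unmeasured compound 4, `Fc1ccccc1OCC1=NCCO1`, differs from compound 1 in one place: fluoro in place of methyl on an aromatic carbon. Among the measured compounds shown here, no measured pair shows this kind of swap; the only step on record puts a methyl in place of a hydrogen and did not move the read-out beyond the scatter. Nothing in the data therefore argues for a step of any size in this assay, and the expected step of a number 2 percentage points higher from compound 1 to compound 4 (within the scatter) is taken as no change beyond the scatter. Compound 4 is estimated at 12%, with a range from 0% to 25%.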

Compound 4, a percentage reported as activity, at one dose (the size of the read-out at that dose, not a potency): 10%
Estimate against measurement, compound 4: 2 percentage points above, within the range that was stated.
By their numbers in this assay, from the lowest: compounds 1, 4, 2 and 3 (each within the scatter of the next).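

Among these compounds, until now, the only single-place step on record put a methyl in place of a hydrogen; compound 4 is the first to show a change to the methyl of compound 1 itself, on the aromatic carbon ortho to a group of 7 heavy atoms. Exchanging that methyl for fluoro, one heavy atom for another, gives a step in this assay of no change at the digits printed from compound 1 to compound 4 (within the scatter) and so leaves the read-out within the scatter, which means that in this one pair the methyl is not needed to keep the number where it stands. No measurement shown here offers an explanation for this result, so it remains an observation about a single pair at a single dose.

Fluoro and methyl are both small groups of one heavy atom, so it remains open whether a larger or very different group on this same carbon, such as an amine, a carboxylic acid or a longer chain, would move the read-out beyond the scatter. From the compounds shown here alone, it is also open whether the same swap would behave alike on the other ring positions carrying a methyl in compound 2 and compound 3.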